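Two methoxy groups in place of one on the aryl arm

The source may hold more compounds than are shown below. What is called first, only, known or untested is meant among the compounds shown, and "the series" means these compounds.

The series shares one core, shown in compound 2 `COc1ccc(C=c2s/c(=C3\C(=O)Nc4cc(F)ccc43)n(CCN(C)C)c2=O)cc1`, and is judged in a functional assay on HT-29 cells (Homo sapiens) for inhibition, read by MTT assay, with a stated time of 72 h; a lower number here means a stronger inhibitor, a higher number a weaker inhibitor. Compound 1 `CCN(CC)CCCn1c(=O)c(=Cc2ccc(F)cc2F)s/c1=C1\C(=O)Nc2ccc(Cl)cc21` carries a diethylaminopropyl chain and a difluorophenyl group; in this assay compound 1 returns only a limit, > 200000 nM, not a number. That reading is the limit of > 200000 nM in this assay, at which 1 of the 3 values shown sits. Compound 2 gives 2300 nM in this assay, the lowest of the two numbers recorded. Compound 3 `COc1cc(C=c2s/c(=C3\C(=O)Nc4ccc(F)cc43)n(CCN(C)C)c2=O)cc(OC)c1OC`, with a trimethoxyphenyl group and the fluorine set differently on its core, gives 2530 nM in this assay, a value that lies within the scatter of compound 2, so no order can be claimed between them.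

Compound 4 `COc1ccc(OC)c(C=c2s/c(=C3\C(=O)Nc4cc(F)ccc43)n(CCN(C)C)c2=O)c1` has not yet been measured in this assay. It differs from compound 2 at one place: 2,5-dimethoxyphenyl in place of 4-methoxyphenyl on a double-bonded chain carbon bound to an aromatic carbon. Going by the values given here, no measured pair in this set differs at only that place, so the size of the step is open. Since compound 3 with three methoxy groups gives 2530 nM, close to compound 2, a second methoxy group on the same aryl arm is expected to move the value little. Compound 4 is therefore estimated at 2800 nM in this assay, between 900 nM and 9000 nM, a step of a 1.2-fold higher number from compound 2 to compound 4 (0.09 log units; within the scatter) that is expected to stay within the scatter.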

Compound 4, half-maximal inhibitory concentration: 4450 nM
Beside the measured number, compound 4's estimate is 1.6-fold (0.20 log units) below it; low and high end bracket the measured number.
By their numbers in this assay, from the lowest: compounds 2, 3 and 4 (each within the scatter of the next). At a limit, above all of these: compound 1.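

Going by these compounds alone, compound 4 and compound 2 form the first pair here that differs at only one place, so this position can now be read on its own in this assay. Putting 2,5-dimethoxyphenyl in place of 4-methoxyphenyl on a double-bonded chain carbon bound to an aromatic carbon gives a 1.9-fold higher number from compound 2 to compound 4 (0.29 log units; within the scatter), so this change of aryl group, with its extra methoxy group and its altered substitution pattern, leaves the reading indistinguishable from that of the parent compound. Within the data shown here, nothing measured in this set offers a cause for this step, and the single pair cannot separate the added methoxy group from the moved one.

From the compounds shown here alone, how an amine or a carboxylic acid on the aryl arm, or an unsubstituted phenyl ring at the same place, would read in this assay remains open, as does the effect of a longer chain in place of the dimethylaminoethyl chain. Compound 1 gives > 200000 nM, which is a limit and not a number, and no pair shown links it to compound 2 through a single place.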